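A few compounds are considered here, and "the series" means these few. Any claim that something is new, unique, unknown or untested is made for them only; others in the source may bear on it.

Measured in a functional assay on MDA-MB-231 cells (Homo sapiens) for antiproliferative activity, read by MTT assay, with a stated time of 72 h (a lower number here means a stronger inhibitor, a higher number a weaker inhibitor), so far:
Compound 1 `O=C(CCc1cccc2c1B(O)OC2)Nc1cccc(Br)c1`: 720 nM
Compound 2 `O=C(CCc1cccc2c1B(O)OC2)Nc1cccc(-c2ccc(Cl)cc2)c1`: 260 nM

Of these two numbers, compound 2 at 260 nM is the lower. Compound 3 `COc1cc(OC)cc(-c2cccc(NC(=O)CCc3cccc4c3B(O)OC4)c2)c1` has 3,5-dimethoxyphenyl in place of 4-chlorophenyl on an aromatic carbon. Among the compounds with values here, only one measured step bears on this change, the modest 2.8-fold lower number from compound 1 to compound 2 (0.44 log units; beyond the scatter) on going from bromo to 4-chlorophenyl. Within the data shown here, no measured pair exchanges one substituted phenyl for another, so no step beyond the scatter is expected in this assay in either direction. The expected step is a 1.2-fold higher number from compound 2 to compound 3 (0.06 log units; within the scatter) in size. For compound 3 the estimated value is 300 nM (expected range 100 nM to 900 nM).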

Compound 3, half-maximal inhibitory concentration: 40 nM
Beside the measured number, compound 3's estimate is 7.5-fold (0.88 log units) above it; the whole stated range lies above it.
By their numbers in this assay, from the lowest: compound 3; then compound 2; then compound 1.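

In this assay, the step of a 6.5-fold lower number from compound 2 to compound 3 (0.81 log units; beyond the scatter) shows that the choice of substituents on the phenyl group at this aromatic carbon matters, which the earlier bromo to 4-chlorophenyl step could not show. The step of an 18-fold lower number from compound 1 to compound 3 (1.26 log units; beyond the scatter) is larger than the one that 4-chlorophenyl gave. Nothing available explains why 3,5-dimethoxyphenyl gives the lower number.

From the compounds shown here alone, whether both methoxy groups are needed remains open. So does whether a pyridine ring or an aminophenyl group at this carbon would give a similar number.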